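The source may report more compounds than this note shows. Statements on the series, on what has been measured and on what is new or still open speak of the compounds shown alone.

Measured so far:
Compound 1 `CN(C)C(=O)CNC(=O)c1cn(Cc2ccc(-n3cccn3)cc2)c2cccnc12`: 9.3 mL/min/kg
Compound 2 `Cn1ccc(-c2ccc(Cn3cc(C(=O)N[C@H]4CCOC[C@@H]4O)c4ncccc43)cc2)n1`: 10.6 mL/min/kg
Compound 3 `O=C(N[C@H]1CCCC[C@@H]1O)c1cn(Cc2ccc(-n3cc(-c4ccncc4)cn3)cc2)c2cccnc12`: 140 mL/min/kg

Three compounds have been run in an ADME assay on liver for metabolic stability, with Liver microsome (Homo sapiens) as the target, using microsomes; on this read-out lower numbers stand for slow clearance and higher numbers for fast clearance. Compound 1 gives the lowest of the three numbers, 9.3 mL/min/kg. Compound 2, at 10.6 mL/min/kg, sits within the usual scatter of compound 1, so the two cannot be told apart on this read-out. Compound 3, at 140 mL/min/kg, stands far above both, well beyond the scatter. Within the data shown here, no pair of measured compounds differs in a single place, so no measured step is available to guide the change considered here.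

Compound 4 `O=C(NCC1(O)CCC1)c1cn(Cc2ccc(-n3cccn3)cc2)c2cccnc12` has not yet been measured. It differs from compound 1 by 1-hydroxycyclobutyl in place of dimethylcarbamoyl on a saturated chain carbon bound to an amide-type nitrogen. Among the measured compounds shown here, nothing among the measured compounds shows what this change does in this assay. Compound 1 at 9.3 mL/min/kg is the only anchor. Only a small change is expected, a 1.3-fold higher number from compound 1 to compound 4 (0.11 log units; within the scatter), not clearly beyond the scatter in either direction. Compound 4 is therefore estimated at 12 mL/min/kg, with a range from 6 mL/min/kg to 25 mL/min/kg.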

Compound 4, clearance: 17 mL/min/kg
Estimate against measurement, compound 4: 1.4-fold (0.15 log units) below, and the stated range covers the measured number.
By their numbers in this assay, from the lowest: compounds 1, 2 and 4 (each within the scatter of the next); then compound 3.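

In this assay, placing 1-hydroxycyclobutyl where dimethylcarbamoyl stood, on a saturated chain carbon bound to an amide-type nitrogen, gives a 1.8-fold higher number from compound 1 to compound 4 (0.26 log units; within the scatter) and so no change that can be told apart from repeat scatter. Among these compounds, this is the first measured step at this position, and it shows that a group with a four-membered carbon ring and a hydrogen-bond donor can replace one with no ring and no donor while the read-out stays within that scatter. Nothing measured here explains this result.

The ring and the hydroxyl enter together, so the compounds shown leave open what each contributes alone. Plain cyclobutyl, with no hydroxyl, would help separate the two, and a carboxylic acid or a primary amine on the same chain carbon would test a different kind of group at this position.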